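Adding a phenyl group to a well-tolerated compound

A few compounds are considered here, and "the series" means these few. Any claim that something is new, unique, unknown or untested is made for them only; others in the source may bear on it.

In a toxicity assay on MDCK cells (Canis lupus familiaris) for cytotoxicity, read by CCK-8 assay, with a stated time of 48 h (a higher number here means that more compound is tolerated, a lower number that less compound is tolerated), compound 1 `COc1ccc(C(=O)NNc2c(Br)cccc2Br)cc1` gives > 100000 nM, which is a limit of the assay and not a number. Compound 2 `O=C(NNc1c(Br)cccc1Br)c1ccccc1` gives > 100000 nM, which is also a limit. The whole picture so far is the limit of > 100000 nM in this assay, at which 2 of the 2 values shown sit.

Within the data shown here, the one measured step, replacing methoxy with hydrogen on an aromatic carbon, is a step that the two limits leave unreadable from compound 1 to compound 2. It offers no size to carry forward.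

Compound 3 `O=C(NNc1c(Br)cccc1Br)c1ccc(-c2ccccc2)cc1` departs from compound 2 by one change: phenyl in place of hydrogen on an aromatic carbon. This places phenyl where hydrogen stood on an aromatic carbon, para to a large group.

With no readable step to guide it, the expectation in this assay is no shift beyond the scatter, in either direction. The expected move is a number no higher from compound 2 to compound 3 (the limit leaves the size open). For compound 3 the estimated value is 100000 nM, with an expected range from 35000 nM to 250000 nM.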

Compound 3, half-maximal cytotoxic concentration: 84100 nM
Compound 3: middle estimate off by 1.2-fold (0.08 log units), on the high side, and the stated range covers the measured number.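

In this assay, among these compounds, compound 3 gives 84100 nM, the first value in this set that is a number and not a limit of the assay. Placing phenyl on this aromatic carbon gives an at least 1.1-fold lower number from compound 2 to compound 3 (0.07 log units; that floor lies within the scatter), and the same place with phenyl instead of methoxy gives an at least 1.1-fold lower number from compound 1 to compound 3 (0.07 log units; that floor lies within the scatter). From the compounds shown here alone, these steps are known only as floors, so a large added ring at this place shows no change beyond the scatter, and their full size stays unknown because the other compounds sit at a limit: the limit of > 100000 nM in this assay, at which 2 of the 3 values shown sit.

Going by these compounds, what stays open is whether the toxicity seen at this number depends on the added ring itself. An amine or a carboxylic acid on the same aromatic carbon could give a quite different reading.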